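A few compounds are considered here, and "the series" means these few. Any claim that something is new, unique, unknown or untested is made for them only; others in the source may bear on it.

Measured so far in an ADME assay on HEL cells (Homo sapiens) for cytotoxicity, read by microscopy; on this read-out higher numbers stand for lower toxicity in this test and lower numbers for higher toxicity in this test:
compound 1 `O=c1ccn(CCCCCOc2ccc([N+](=O)[O-])cc2)c(=O)[nH]1`, 20000 nM
compound 2 `CCCOC(=O)c1ccc(OCCCCCn2ccc(=O)[nH]c2=O)cc1`, a limit of the assay, >= 100000 nM
compound 3 `O=c1ccn(CCCOc2ccc(Br)cc2)c(=O)[nH]1`, a limit of the assay, > 100000 nM

Compound 2 stands at one of the two limits among the three numbers, so its figure is a bound rather than a reading; compound 3 also sits at a limit, and only compound 1 gives a plain number. The step toward compound 4 `Nc1ccc(OCCCCCn2ccc(=O)[nH]c2=O)cc1` is amino in place of propoxycarbonyl on an aromatic carbon. Among the compounds with values here, no measured step removes propoxycarbonyl or introduces amino, so none bears on it directly. Within the data shown here, the single measured step in this assay, an at least 5.0-fold higher number from compound 1 to compound 2 (0.69 log units; beyond the scatter), shows that exchanging the group on that aromatic carbon moved the read-out beyond the scatter, but it is itself bounded by a limit (the limit of >= 100000 nM in this assay, at which 1 of the 3 values shown sits), and the amino change has no counterpart among the measured pairs. With compound 2 already at its limit, only a move toward lower numbers could appear as a figure. Compound 4 is expected to give 100000 nM (range 30000 nM to 300000 nM), with a fair chance that the result is again only a limit. For compound 4 the implied step a number no higher from compound 2 to compound 4 (the limit leaves the size open) is likewise an expectation, not a reading.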

Compound 4, minimum cytotoxic concentration: > 100000 nM
Compound 4 gave a limit, no number; the forecaster's own chance of this, stated with the estimate: 60%; the middle value sits exactly at the limit.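

In this assay compound 4 gives > 100000 nM as a limit of the assay, not a number. Amino in place of nitro gives an at least 5.0-fold higher number from compound 1 to compound 4 (0.69 log units; beyond the scatter) on this aromatic carbon, and with an at least 5.0-fold higher number from compound 1 to compound 2 (0.69 log units; beyond the scatter) as the earlier case, two different replacements of nitro now move the read-out beyond the scatter. The step between compound 2 and compound 4 cannot be read, as both values are limits, so these two replacements cannot be ranked against each other.

Within the data shown here, what compound 2 and compound 4 would read past their limits stays open, which leaves nitro as the only group at this position with a plain number. Also open, from the compounds shown here alone, is whether a carboxylic acid or a hydroxyl on this aromatic carbon would end at the limit or give a number, as compound 1 does.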